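Swapping benzylamino for methoxy on a weak inhibitor

The source may report more compounds than this note shows. Statements on the series, on what has been measured and on what is new or still open speak of the compounds shown alone.

Values measured so far in a functional assay on PC-3 cells (Homo sapiens) for inhibition, read by sulforhodamine B assay, with a stated time of 72 h (on this read-out higher numbers stand for weaker inhibition and lower numbers for stronger inhibition), are these:
Compound 1 `Nc1sc(-c2ccc(Cl)cc2)c(-c2ccc(Cl)cc2)c1C(=O)NC1CCC(O)CC1` gives 5670 nM
Compound 2 `Nc1sc(-c2ccc(Cl)cc2)c(-c2ccc(Cl)cc2)c1C(=O)N1CCCC1` gives 6220 nM
Compound 3 `Nc1sc(-c2ccc(Cl)cc2)c(-c2ccc(Cl)cc2)c1C(=O)NCc1ccccc1` gives 31800 nM

Compound 3 has the highest number of the three at 31800 nM and so shows the weakest inhibition. Compound 4 `COC(=O)c1c(N)sc(-c2ccc(Cl)cc2)c1-c1ccc(Cl)cc1` keeps the shared core but has methoxy in place of benzylamino on a carbonyl carbon. For the measured compounds named here, two measured steps bear on this change, since both end at the benzylamino compound (a 5.6-fold higher number from compound 1 to compound 3 (0.75 log units; beyond the scatter); a 5.1-fold higher number from compound 2 to compound 3 (0.71 log units; beyond the scatter)). Each is modest and beyond the scatter. The two groups that gave the lower numbers differ widely yet stay level (a 1.1-fold higher number from compound 1 to compound 2 (0.04 log units; within the scatter)), so leaving benzylamino may matter more than what replaces it. Going by the values given here, no methoxy compound has been measured, which leaves the size of the step uncertain. A modest move to a lower number is therefore expected in this assay. The expected change is (a 2.7-fold lower number from compound 3 to compound 4 (0.42 log units; beyond the scatter)). Compound 4 is estimated at 12000 nM with an expected range from 3500 nM to 40000 nM in this measurement.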

Compound 4, half-maximal inhibitory concentration: 2780 nM
The estimate for compound 4 lay 4.3-fold (0.64 log units) above the measured number; measured number below the stated range.
By their numbers in this assay, from the lowest: compound 4; then compounds 1 and 2 (each within the scatter of the next); then compound 3.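

In this assay, methoxy on this carbonyl carbon gives the lowest number of the set, with an 11-fold lower number from compound 3 to compound 4 (1.06 log units; beyond the scatter) as a large step, while a 2.2-fold lower number from compound 2 to compound 4 (0.35 log units; beyond the scatter) and a 2.0-fold lower number from compound 1 to compound 4 (0.31 log units; beyond the scatter) are modest steps that still lie beyond the scatter. The earlier compounds shown here showed only that moving away from benzylamino lowered the number, whereas this result shows that the group taking its place can matter too, and that the position needs neither a nitrogen nor a ring to reach the lowest number so far. Nothing measured here explains why methoxy behaves this way.

Going by these compounds, it remains open whether ethoxy, a free carboxylic acid or a simple methylamino group on the same carbonyl carbon would match methoxy. On these data alone, it is also open whether the same order would hold if the groups on the rest of the shared core were changed.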